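Series notes: cyclohexyl in place of 2-methylprop-2-en-1-yl

The compounds below may be only part of what the source reports. "The series", "measured", "known", "first", "only" and "open" are said of these compounds alone.

Of the compounds shown here, three on the shared core have been measured in a functional assay on NCI-H1299 cells (Homo sapiens) for cytotoxicity, read by MTT assay, with a stated time of 48 h; a lower number here means a stronger inhibitor, a higher number a weaker inhibitor. Compound 1 `O=C1C[C@H](OCc2cn(-c3ccc(Cl)cc3)nn2)[C@H]2CO[C@@H]1O2` gives 10600 nM, compound 2 `O=C1C[C@H](OCc2cn(-c3ccccc3)nn2)[C@H]2CO[C@@H]1O2` gives 10900 nM, and compound 3 `C=C(C)Cn1cc(CO[C@H]2CC(=O)[C@@H]3OC[C@H]2O3)nn1` gives 14300 nM. Compound 3 thus carries the highest of the three numbers, yet its separation from compound 2 is a 1.3-fold higher number from compound 2 to compound 3 (0.12 log units; within the scatter) and from compound 1 is a 1.3-fold higher number from compound 1 to compound 3 (0.13 log units; within the scatter), both within the scatter, so no ordering among the three is supported. The comparison of compound 1 with compound 2, a 1.0-fold higher number from compound 1 to compound 2 (0.01 log units; within the scatter), likewise shows nothing beyond the scatter.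

Compound 4 `O=C1C[C@H](OCc2cn(C3CCCCC3)nn2)[C@H]2CO[C@@H]1O2` is not yet measured. Its change from compound 3 is cyclohexyl in place of 2-methylprop-2-en-1-yl on an aromatic nitrogen. The measured steps that bear on this are the two that exchange the group on the same aromatic nitrogen: a 1.3-fold higher number from compound 1 to compound 3 (0.13 log units; within the scatter) and a 1.3-fold higher number from compound 2 to compound 3 (0.12 log units; within the scatter). Both are within the scatter, whether the group is an aromatic ring or an open chain, so no direction is indicated for the entry of cyclohexyl at this position. The expectation for compound 4 in this assay is therefore a step of a 1.2-fold lower number from compound 3 to compound 4 (0.08 log units; within the scatter), that is, a number near that of compound 3. Compound 4 is estimated at 12000 nM, with a range from 5000 nM to 30000 nM.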

Compound 4, half-maximal inhibitory concentration: 12000 nM
Beside the measured number, compound 4's estimate shows no gap at the digits printed; measured number inside the range.
By their numbers in this assay, from the lowest: compounds 1, 2, 4 and 3 (each within the scatter of the next).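

In this assay, a six-membered non-aromatic ring of carbon only now stands on the aromatic nitrogen, and its exchange for the open chain gives a 1.2-fold lower number from compound 3 to compound 4 (0.08 log units; within the scatter) with no separation from compound 3. Exchanged for the aromatic groups, cyclohexyl gives a 1.1-fold higher number from compound 2 to compound 4 (0.04 log units; within the scatter) in place of phenyl and a 1.1-fold higher number from compound 1 to compound 4 (0.05 log units; within the scatter) in place of 4-chlorophenyl, so across these four compounds an open chain with a double bond, a non-aromatic ring and two aromatic rings on this nitrogen show no step beyond the scatter. No measurement is available that could account for this lack of separation, and none is offered here.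

Open, from the compounds shown here alone, is whether a group on this nitrogen that carries an amine or a carboxylic acid, or a longer chain, would move the number beyond the scatter. Also open, going by these compounds, is whether a change elsewhere on the shared core, such as replacement of its carbonyl, would separate compounds in a way that exchanges at this nitrogen have not.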